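Swapping a butylsulfanyl arm for a cyclohexylamine

This account rests on a few compounds, and the source may have more. Where it says the series, first, only, none or still open, it means among the compounds named here.

Compound 1, `CCCCN1CCN(C(=S)SC(=S)N(C)C)CC1`: 4100000 nM
Compound 2, `CCCCSC(=S)N1CCN(C(=S)SC(=S)N(C)C)CC1`: > 5000000 nM

In an ADME assay on HeLa cells (Homo sapiens) for cytotoxicity, read by MTT assay, with a stated time of 24 h (a lower number here means a stronger inhibitor, a higher number a weaker inhibitor), compound 1 gives 4100000 nM. Compound 2 reaches only a limit of the assay, > 5000000 nM, so no exact number is known for it. It stands at the limit of > 5000000 nM in this assay, at which 1 of the 2 values shown sits. Going by the values given here, the one measured step, an at least 1.2-fold higher number from compound 1 to compound 2 (0.08 log units; that floor lies within the scatter), puts a butylsulfanyl-thiocarbonyl arm in place of a butyl group on a ring amine nitrogen, and its floor lies within the scatter.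

Compound 3, `CN(C)C(=S)SC(=S)N1CCN(C(=S)NC2CCCCC2)CC1`, differs from compound 2 by cyclohexylamino in place of butylsulfanyl on a thiocarbonyl carbon. Among the compounds with values here, this change sits at a different place from the one measured step, so that step speaks to it only indirectly: both measured compounds sit at very high numbers in this assay, and the single measured change moved the number little if at all. The step is therefore expected to be none beyond the scatter, a number no higher from compound 2 to compound 3 (the limit leaves the size open), with a real chance that this assay again reports only a limit. Compound 3 is estimated at 5000000 nM, within a range of 2000000 nM to 15000000 nM.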

Compound 3, half-maximal inhibitory concentration: > 5000000 nM
Compound 3 ended at the assay's limit; the forecaster's own chance of this, stated with the estimate: 60%; the middle value lies on the limit itself.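

Going by these compounds alone, compound 2 and compound 3 each reach only a limit in this assay, so no step between them can be read, and cyclohexylamino in place of butylsulfanyl has no readable size. Going by these compounds, what stays open is how far past that limit either compound truly lies, and whether this change moves the number at all.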